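A few compounds are considered here, and "the series" means these few. Any claim that something is new, unique, unknown or untested is made for them only; others in the source may bear on it.

Compound 2, `CCCNC(=O)c1cc(Oc2ccc(NC(=O)c3cc4cccnc4n(-c4ccc(F)cc4)c3=O)cc2)ccn1`, gives 84 nM in a functional assay on HT-29 cells (Homo sapiens) for antiproliferative activity, read by MTT assay, with a stated time of 72 h (on this read-out lower numbers stand for stronger inhibition and higher numbers for weaker inhibition), the lower of the two numbers measured. Compound 1, `CCNC(=O)c1cc(Oc2ccc(NC(=O)c3cc4cccnc4n(-c4ccc(Br)cc4)c3=O)cc2)ccn1`, gives 1160 nM in this assay; it differs from compound 2 in two places, so the two values show only that the gap between them lies beyond the scatter. Compound 3, `CCCNC(=O)c1cc(Oc2ccc(NC(=O)c3cc4cccnc4n(-c4ccc(Br)cc4)c3=O)cc2)ccn1`, is not yet measured; it carries bromo in place of fluoro on an aromatic carbon, the change that takes compound 2 toward the bromo substituent of compound 1. Because compound 1 gives 1160 nM, a weakening step a 3.6-fold higher number from compound 2 to compound 3 (0.55 log units; beyond the scatter) is expected, though its size is uncertain. Compound 3 is estimated at 300 nM, within 80 nM to 1200 nM.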

Compound 3, half-maximal inhibitory concentration: 530 nM
Compound 3: middle estimate off by 1.8-fold (0.25 log units), on the low side; the measured number falls inside the stated range.
By their numbers in this assay, from the lowest: compound 2; then compound 3; then compound 1.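

In this assay, bromo in place of fluoro on the ring weakens inhibition with the amide chain held constant, giving a 6.3-fold higher number from compound 2 to compound 3 (0.80 log units; beyond the scatter). Methyl in place of hydrogen on the chain, with the bromo held constant, strengthens it, giving a 2.2-fold lower number from compound 1 to compound 3 (0.34 log units; beyond the scatter), so each of the two changes separating compound 1 and compound 2 has a step of its own beyond the scatter. Nothing measured here explains either step. Still open, from the compounds shown here alone, is how a chloro group or plain hydrogen at this ring position would compare, and whether a butyl chain on the amide would extend the gain.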